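The source may hold more compounds than are shown below. What is called first, only, known or untested is meant among the compounds shown, and "the series" means these compounds.

Of the compounds shown here, three have been measured in a functional assay on HeLa cells (Homo sapiens) for antiproliferative activity, read by sulforhodamine B assay; on this read-out higher numbers stand for weaker inhibition of growth and lower numbers for stronger inhibition of growth. Compound 1 `CCC[C@@H]1O[C@H](COCc2ccc3ccccc3c2)[C@@H](OCc2ccc3ccccc3c2)[C@H](OCc2ccc3ccccc3c2)[C@H]1O` carries a free hydroxy on its core. In this assay compound 1 reaches only the assay limit, > 50000 nM. Compound 2 `CCC[C@@H]1O[C@H](COCc2ccc3ccccc3c2)[C@@H](OCc2ccc3ccccc3c2)[C@H](OCc2ccc3ccccc3c2)[C@H]1OC(C)=O` differs from compound 1 in one place: acetyl in place of hydrogen on an oxygen on a saturated carbon. In this assay compound 2 likewise gives only a limit, > 50000 nM. The step that the two limits leave unreadable from compound 1 to compound 2 cannot be read because the limit of > 50000 nM in this assay, at which 2 of the 3 values shown sit, hides both its size and its direction. Compound 3 `C=CC[C@@H]1O[C@H](COCc2ccccc2)[C@@H](OCc2ccccc2)[C@H](OCc2ccccc2)[C@H]1O` is built on a different core; the difference between the two cores is not broken down here. In this assay, among the compounds with values here, compound 3 gives 26200 nM, the only true number among the three values. Compound 4 `C=CC[C@@H]1O[C@H](COCc2ccccc2)[C@@H](OCc2ccccc2)[C@H](OCc2ccccc2)[C@H]1OC(C)=O` stands to compound 3 as compound 2 stands to compound 1: acetyl in place of hydrogen on an oxygen on a saturated carbon. It is the same change, at a place described in the same words, and it appears for the second time in this set. Within the data shown here, nothing measured shows how large a step it makes; the one earlier example sits wholly at the limit. The step from compound 3 to compound 4 in this assay is therefore expected to be small, a 1.1-fold higher number from compound 3 to compound 4 (0.06 log units; within the scatter). That expectation rests on compound 3, whose value is 26200 nM, and on the absence of any readable earlier step, so it carries wide uncertainty. Compound 4 is expected to give about 30000 nM in this assay. Its estimated range runs from 10000 nM to 100000 nM, with a real chance that only a limit is reported.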

Compound 4, concentration for 50% growth inhibition: > 50000 nM
Compound 4 ended at the assay's limit; the forecaster's own chance of this, stated with the estimate: 35%; middle value at least 1.6-fold (0.22 log units) from the limit.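

In this assay compound 4 gives > 50000 nM, which is a limit of the assay and not a number. Hydroxy to acetoxy on the core of compound 3 therefore appears as an at least 1.9-fold higher number from compound 3 to compound 4 (0.28 log units; that floor lies within the scatter); only this floor is known, so the result fits a real loss of growth inhibition but does not establish one, and the true size of the step stays open. Nor does it show that the change behaves alike on both cores, as the same change on the core of compound 1 gives no step to set beside it, and neither its size nor its direction can be read because of the ceiling of the assay: the limit of > 50000 nM in this assay, at which 3 of the 4 values shown sit.

The compounds shown leave open whether any group other than acetyl, such as an amine, a carboxylic acid or a longer chain, would give a readable value when placed on that oxygen on a saturated carbon. They also leave open how much the difference between the two cores matters on its own, as compound 3 alone gives a true number, 26200 nM, and no pair shown isolates that difference.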